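Trimming the Side-Chain Linker: From Compound 2 to Compound 4

This account rests on a few compounds, and the source may have more. Where it says the series, first, only, none or still open, it means among the compounds named here.

Measured in an assay on HEK293 cells for displacement of a labelled ligand from 5-hydroxytryptamine receptor 6 (Homo sapiens); on this read-out lower numbers stand for stronger inhibition and higher numbers for weaker inhibition:
Compound 1, `O=[N+]([O-])c1ccc(N2CCNCC2)cc1NCCOc1ccc(Cl)cc1`: 290 nM
Compound 2, `O=[N+]([O-])c1ccc(N2CCNCC2)cc1NCCOc1ccccc1`: 114 nM
Compound 3, `Cc1cc(C)n(-c2cc(N3CCNCC3)ccc2[N+](=O)[O-])n1`: 482 nM

Compound 2 gives the lowest number of the three in this assay. Its nearest neighbour is compound 1, and the step from compound 1 to compound 2 is a 2.5-fold lower number from compound 1 to compound 2 (0.41 log units; beyond the scatter). Compound 3, which carries a pyrazole in place of the whole aminoethoxyphenyl side chain, gives a higher number than compound 2 in this assay, but that pair differs in more than one place and is not treated as a single step.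

Compound 4, `O=[N+]([O-])c1ccc(N2CCNCC2)cc1NCc1ccccc1`, differs from compound 2 by phenyl in place of phenoxymethyl on a saturated chain carbon bound to a nitrogen on an aromatic ring. Among the measured compounds shown here, the only measured single step, a 2.5-fold lower number from compound 1 to compound 2 (0.41 log units; beyond the scatter), concerns a substituent on the distal ring rather than the linker, so no step bears directly on this change. Compound 3 merely shows that a different side chain can raise the number. The expectation for compound 4 is therefore a modest rise, a step of a 2.2-fold higher number from compound 2 to compound 4 (0.34 log units; beyond the scatter), with little confidence in the direction. Compound 4 is estimated at 250 nM in this assay, in a range from 60 nM to 1000 nM.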

Compound 4, inhibition constant: 28 nM
The estimate for compound 4 lay 8.9-fold (0.95 log units) above the measured number; measured number below the stated range.
By their numbers in this assay, from the lowest: compound 4; then compound 2; then compounds 1 and 3 (each within the scatter of the next).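

In this assay, the side chain itself proves to be a sensitive place: phenyl in place of phenoxymethyl on a saturated chain carbon bound to a nitrogen on an aromatic ring gives a 4.1-fold lower number from compound 2 to compound 4 (0.61 log units; beyond the scatter). The earlier single step concerned only a substituent on the distal ring, whereas this one shows that the number also moves when the link to that ring changes. Phenoxymethyl carries 8 heavy atoms and 1 hydrogen-bond acceptor, phenyl 6 heavy atoms and 0 hydrogen-bond acceptors, and nothing available explains why this change lowers the number.

These compounds do not separate the loss of the oxygen from the shortening of the chain, which a phenethyl group in the same place could address. From the compounds shown here alone, whether a chloro on the ring of compound 4 would raise the number, as it does on compound 2, also remains open.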